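The source may hold more compounds than are shown below. What is called first, only, known or untested is meant among the compounds shown, and "the series" means these compounds.

Compound 1 `COc1cc(/C=C2\CN(S(=O)(=O)c3ccc(NC(C)=O)cc3)C/C(=C\c3ccccc3F)C2=O)cc(OC)c1`: 6800 nM
Compound 2 `COc1cc(/C=C2\CN(S(=O)(=O)c3ccc(NC(C)=O)cc3)C/C(=C\c3cccc([N+](=O)[O-])c3)C2=O)cc(OC)c1OC`: 3340 nM

In a functional assay on HepG2 cells (Homo sapiens) for cytotoxicity, read by MTT assay, with a stated time of 24 h (on this read-out lower numbers stand for stronger inhibition and higher numbers for weaker inhibition), compound 2 holds the lower of the two numbers at 3340 nM, a gap from compound 1 that lies just beyond the usual scatter. Compound 3 `COc1cc(/C=C2\CN(S(=O)(=O)c3ccc(NC(C)=O)cc3)C/C(=C\c3cc(OC)c(OC)c(OC)c3)C2=O)cc(OC)c1` has not yet been measured. It departs from compound 2 in one place, with 3,5-dimethoxyphenyl in place of 3-nitrophenyl on a double-bonded chain carbon bound to a double-bonded ring carbon. Among the compounds with values here, no measured pair shows this change alone, so any expectation is loose. Compound 1, which also carries 3,5-dimethoxyphenyl, reads 6800 nM, so a somewhat higher number than for compound 2 is expected. The estimated 1.5-fold higher number from compound 2 to compound 3 (0.18 log units; within the scatter) would be small and would not clearly exceed the scatter. For compound 3 the expected value is 5000 nM, with an estimated range of 2000 nM to 12000 nM.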

Compound 3, half-maximal inhibitory concentration: 4140 nM
Compound 3: middle estimate off by 1.2-fold (0.08 log units), on the high side; the measured number falls inside the stated range.
By their numbers in this assay, from the lowest: compounds 2, 3 and 1 (each within the scatter of the next, the first and the last beyond it).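

Within the data shown here, these are the first single-change comparisons at this place, and neither moves the number beyond the scatter. In this assay, 3,5-dimethoxyphenyl in place of 3-nitrophenyl on a double-bonded chain carbon bound to a double-bonded ring carbon gives a 1.2-fold higher number from compound 2 to compound 3 (0.09 log units; within the scatter), while 3,4,5-trimethoxyphenyl in place of 2-fluorophenyl at that place gives a 1.6-fold lower number from compound 1 to compound 3 (0.22 log units; within the scatter). Among these three compounds, then, both exchanges of one substituted phenyl group for another leave the read-out within the scatter, and nothing measured here accounts for that.

All the groups compared at this place are substituted phenyl rings. From the compounds shown here alone, how a phenyl ring bearing an amine or a carboxylic acid, or an open alkyl chain in place of the ring, would read remains open.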